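The source may hold more compounds than are shown below. What is called first, only, known or untested is meant among the compounds shown, and "the series" means these compounds.

Measured in a functional assay on HT-29 cells (Homo sapiens) for antiproliferative activity, read by MTT assay, with a stated time of 72 h; a lower number here means a stronger inhibitor, a higher number a weaker inhibitor:
- Compound 1 `CCCn1ccnc1-c1cc(OC)c(OC)c(OC)c1`: > 100000 nM
- Compound 2 `COc1cc(-c2nccn2C(C)C)cc(OC)c1OC`: > 100000 nM
- Compound 3 `COc1cccc(-n2ccnc2-c2cc(OC)c(OC)c(OC)c2)c1`: 18900 nM

Compound 1 and compound 2 sit at a limit of the assay, not at a number: the limit of > 100000 nM in this assay, at which 2 of the 3 values shown sit. Going by the values given here, compound 3, at 18900 nM, has the only true number and stands ahead of both.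

Compound 4 `COc1cc(-c2nccn2-c2ccc(F)cc2)cc(OC)c1OC` brings one change: 4-fluorophenyl in place of 3-methoxyphenyl on an aromatic nitrogen. The closest evidence is an at least 5.2-fold lower number from compound 1 to compound 3 (0.72 log units; beyond the scatter) and an at least 5.2-fold lower number from compound 2 to compound 3 (0.72 log units; beyond the scatter), where 3-methoxyphenyl replaced propyl or isopropyl. In compound 4, one six-membered aromatic ring of carbon only stays on that nitrogen, so no step beyond the scatter is expected in this assay. Among the compounds with values here, neither direction can be favoured, as no measured step tests this swap.

Compound 4 is expected at about 22000 nM, with an estimated range of 7000 nM to 80000 nM. The estimated step is a 1.2-fold higher number from compound 3 to compound 4 (0.07 log units; within the scatter).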

Compound 4, half-maximal inhibitory concentration: 29300 nM
For compound 4 the middle estimate is 1.3-fold (0.12 log units) below the measured one; the range from low to high includes it.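

Swapping 3-methoxyphenyl for 4-fluorophenyl on the aromatic nitrogen gives no step beyond the scatter in this assay: a 1.6-fold higher number from compound 3 to compound 4 (0.19 log units; within the scatter). The advantage over the small chains is therefore not unique to 3-methoxyphenyl: an at least 3.4-fold lower number from compound 2 to compound 4 (0.53 log units; beyond the scatter) and an at least 3.4-fold lower number from compound 1 to compound 4 (0.53 log units; beyond the scatter). Both of these steps are minimum sizes, since compound 1 and compound 2 stand at a limit and not at a number: the limit of > 100000 nM in this assay, at which 2 of the 4 values shown sit.

From the compounds shown here alone, whether plain phenyl on this nitrogen performs like these two rings remains open. So does the effect of a benzyl group, or of an amine or a carboxylic acid on the ring.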